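This account rests on a few compounds, and the source may have more. Where it says the series, first, only, none or still open, it means among the compounds named here.

Measured compounds:
compound 1 `COc1cccc(/C=C/C(=O)c2ccc(OCCn3cc(CN4C(=O)/C=C/C(C)(C)C/C=C(\C)CC/C=C/4C)nn3)cc2O)c1` — 1.12 ug/mL
compound 2 `COc1ccccc1/C=C/C(=O)c1ccc(OCCn2cc(CN3C(=O)/C=C/C(C)(C)C/C=C(\C)CC/C=C/3C)nn2)cc1O` — 1.17 ug/mL

In a functional assay on MCF7 cells (Homo sapiens) for antiproliferative activity (a lower number here means a stronger inhibitor, a higher number a weaker inhibitor), compound 2 gives the highest of the two numbers, and its nearest neighbour is compound 1, which gives 1.12 ug/mL; the two lie within the scatter of each other. Going by the values given here, the only measured step is a 1.0-fold higher number from compound 1 to compound 2 (0.02 log units; within the scatter), which shows that moving the single methoxy group on the aromatic ring left the number where it was.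

Compound 3 `COc1cc(/C=C/C(=O)c2ccc(OCCn3cc(CN4C(=O)/C=C/C(C)(C)C/C=C(\C)CC/C=C/4C)nn3)cc2O)cc(OC)c1OC` has not yet been measured. It differs from compound 2 in one place: 3,4,5-trimethoxyphenyl in place of 2-methoxyphenyl on a double-bonded chain carbon bound to a double-bonded chain carbon. No measured step covers adding two further methoxy groups, so the expectation rests only on the one step shown, which was flat. The step expected in this assay is therefore a 1.3-fold lower number from compound 2 to compound 3 (0.11 log units; within the scatter), with no clear direction beyond the scatter. For compound 3 the estimate is 0.9 ug/mL, with a range from 0.35 ug/mL to 2.5 ug/mL.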

Compound 3, half-maximal inhibitory concentration: 2.78 ug/mL
For compound 3 the middle estimate is 3.1-fold (0.49 log units) below the measured one; the measured number lies above the stated range.
By their numbers in this assay, from the lowest: compounds 1 and 2 (each within the scatter of the next); then compound 3.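

In this assay, the group on this double-bonded chain carbon does matter: the change to 3,4,5-trimethoxyphenyl gives a 2.4-fold higher number from compound 2 to compound 3 (0.38 log units; beyond the scatter) and a 2.5-fold higher number from compound 1 to compound 3 (0.39 log units; beyond the scatter), both modest but beyond the scatter. Moving a single methoxy group had left the number flat, whereas the ring with three methoxy groups makes the compound a weaker inhibitor, so this position does not accept every methoxy-bearing ring equally. No measurement shown here offers a reason for this loss.

The compounds shown cannot separate the number of methoxy groups from their arrangement on the ring, and a ring with two methoxy groups would help to tell these apart. On these data alone, it also remains open how this position would respond to groups other than methoxy, such as a fluorine, an amine or a carboxylic acid on the ring, or to a plain phenyl ring.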